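Swapping the Amide Substituent in a Reductase Inhibitor Series

The source may hold more compounds than are shown below. What is called first, only, known or untested is meant among the compounds shown, and "the series" means these compounds.

Measured in an assay on microsomes from liver for inhibition of 3-hydroxy-3-methylglutaryl-coenzyme A reductase (Rattus norvegicus); a lower number here means a stronger inhibitor, a higher number a weaker inhibitor:
compound 1 `CC(C)c1c(C(=O)NCc2ccccc2)nn(-c2ccc(F)cc2)c1OC[C@@H](O)C[C@@H](O)CC(=O)O` gives 3.8 nM;
compound 2 `CC(C)c1c(C(=O)N2CCCC2c2ccccc2)nn(-c2ccc(F)cc2)c1OC[C@@H](O)C[C@@H](O)CC(=O)O` gives 14 nM;
compound 3 `COCc1cccc(CNC(=O)c2nn(-c3ccc(F)cc3)c(OC[C@@H](O)C[C@@H](O)CC(=O)O)c2C(C)C)c1` gives 31 nM.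

Compound 3 shows the highest number of the three, so it is the weakest inhibitor among them. Compound 4 `CC(C)c1c(C(=O)N(C)Cc2ccc(F)c(F)c2)nn(-c2ccc(F)cc2)c1OC[C@@H](O)C[C@@H](O)CC(=O)O` differs from it in one place: (3,4-difluorobenzyl)(methyl)amino in place of (3-(methoxymethyl)benzyl)amino on a carbonyl carbon. For the measured compounds named here, three measured steps bear on this change. Adding methoxymethyl gave an 8.2-fold higher number from compound 1 to compound 3 (0.91 log units; beyond the scatter), and compound 4 lacks that group. Moving to a tertiary amide gave a 3.7-fold higher number from compound 1 to compound 2 (0.57 log units; beyond the scatter), and exchanging the two amide substituents gave a 2.2-fold higher number from compound 2 to compound 3 (0.35 log units; beyond the scatter). Weighing these, compound 4 is expected to show a lower number than compound 3, a modest step of a 3.1-fold lower number from compound 3 to compound 4 (0.49 log units; beyond the scatter) in this assay. Compound 4 is therefore estimated at 10 nM, with a range from 3 nM to 35 nM.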

Compound 4, half-maximal inhibitory concentration: 5.7 nM
Compound 4: middle estimate off by 1.8-fold (0.24 log units), on the high side, within the range that was stated.
By their numbers in this assay, from the lowest: compounds 1 and 4 (each within the scatter of the next); then compound 2; then compound 3.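

In this assay, a tertiary amide on this carbonyl carbon need not cost much: the change to the (3,4-difluorobenzyl)(methyl)amino group gives a 1.5-fold higher number from compound 1 to compound 4 (0.18 log units; within the scatter) and compound 4 keeps pace with the benzylamino amide. The same group gives a 5.4-fold lower number from compound 3 to compound 4 (0.74 log units; beyond the scatter) and a 2.5-fold lower number from compound 2 to compound 4 (0.39 log units; beyond the scatter) even though compound 2 is also a tertiary amide, so the substituent matters, not the amide type alone. No measurement here explains these differences. Still open, from the compounds shown here alone, is what the amide methyl and the two fluorines each contribute, and whether chlorine on the benzyl ring would serve as well.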